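The source may hold more compounds than are shown below. What is called first, only, known or untested is meant among the compounds shown, and "the series" means these compounds.

Compound 1 `CCN1CCN(c2cc(C)c3cc(NC(=O)c4ccccc4C)ccc3n2)CC1` is the weaker of the two measured compounds in a functional assay on MCF7 cells (Homo sapiens) for antiproliferative activity, read by MTT assay, with a stated time of 72 h; a higher number here means a weaker inhibitor, a lower number a stronger inhibitor: compound 1 gives 10900 nM, whereas compound 2 `Cc1cc(N2CCN(C)CC2)nc2ccc(NC(=O)c3ccc(Cl)c(Cl)c3)cc12` gives 3000 nM in this assay, a gap beyond the scatter. Compound 3 `CCN1CCN(c2cc(C)c3cc(NC(=O)c4ccc5ccccc5n4)ccc3n2)CC1` has not yet been measured. It differs from compound 1 in one place: quinolin-2-yl in place of 2-methylphenyl on a carbonyl carbon. Among the compounds with values here, with no measured pair showing this change, only a modest drop in the number is expected, near the edge of the scatter. For compound 3 in this assay the expected value is 5000 nM, between 1500 nM and 15000 nM, which would mean a step of a 2.2-fold lower number from compound 1 to compound 3 (0.34 log units; beyond the scatter).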

Compound 3, half-maximal inhibitory concentration: 7060 nM
Compound 3: middle estimate off by 1.4-fold (0.15 log units), on the low side, within the range that was stated.
By their numbers in this assay, from the lowest: compound 2; then compounds 3 and 1 (each within the scatter of the next).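

In this assay, within the data shown here, replacing 2-methylphenyl with quinolin-2-yl on a carbonyl carbon gives the first single-place step at this position, a 1.5-fold lower number from compound 1 to compound 3 (0.19 log units; within the scatter). The swap brings in a second six-membered aromatic ring, a ring nitrogen and a hydrogen-bond acceptor, yet compound 3 does not separate from compound 1 in this read-out. No available evidence bears on this result. Still open, as far as these compounds go, is whether naphthalen-2-yl, lacking the ring nitrogen, would behave like quinolin-2-yl, and whether an aliphatic amine or a carboxylic acid at this place would move the number beyond the scatter.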